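This account rests on a few compounds, and the source may have more. Where it says the series, first, only, none or still open, it means among the compounds named here.

Measured so far:
compound 1, `O=C(/C(=C\c1ccc([N+](=O)[O-])c(O)c1)Sc1ccc(Br)cc1)c1c(F)c(F)c(F)c(F)c1F`, 1000 nM
compound 2, `O=C(/C(=C\c1ccc(O)c([N+](=O)[O-])c1)Sc1ccc(Br)cc1)c1c(F)c(F)c(F)c(F)c1F`, 1000 nM
compound 3, `O=C(O)c1cc(/C=C(/Sc2ccc(Br)cc2)C(=O)c2c(F)c(F)c(F)c(F)c2F)ccc1O`, 25000 nM

These three compounds share one core and differ only in the substituted phenyl ring that hangs from the double-bonded chain carbon. In a functional assay on DU-145 cells (Homo sapiens) for inhibition, read by trypan blue exclusion, with a stated time of 96 h (on this read-out higher numbers stand for weaker inhibition of growth and lower numbers for stronger inhibition of growth), compound 1 and compound 2 give the same number, and the step of no change at the digits printed from compound 1 to compound 2 (within the scatter) confirms that swapping the positions of hydroxy and nitro on that ring made no difference. Compound 3 stands apart: its number is the highest of the three, as shown by a 25-fold higher number from compound 1 to compound 3 (1.40 log units; beyond the scatter) and by a 25-fold higher number from compound 2 to compound 3 (1.40 log units; beyond the scatter).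

Compound 4, `O=C(/C(=C\c1ccc(O)c(Br)c1)Sc1ccc(Br)cc1)c1c(F)c(F)c(F)c(F)c1F`, is not yet measured. It differs from compound 3 by bromo in place of carboxy on an aromatic carbon. Within the data shown here, the one measured step that bears on this is a 25-fold higher number from compound 2 to compound 3 (1.40 log units; beyond the scatter), where carboxy took the place of nitro on that same aromatic carbon and the number rose sharply. Compound 4 instead carries bromo there, a single heavy atom with no hydrogen-bond donor or acceptor. Since the carboxy group was the change that accompanied the weaker result, removing it is expected to bring the number back toward that of compound 1 and compound 2, though bromo resembles neither nitro nor carboxy, so the size is uncertain. The expected step is a 13-fold lower number from compound 3 to compound 4 (1.10 log units; beyond the scatter), a lower number. Compound 4 is therefore estimated at 2000 nM, within a range from 500 nM to 8000 nM.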

Compound 4, concentration for 50% growth inhibition: 1000 nM
For compound 4 the middle estimate is 2.0-fold (0.30 log units) above the measured one, within the range that was stated.
By their numbers in this assay, from the lowest: compounds 1, 2 and 4 (each within the scatter of the next); then compound 3.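

Until now the aromatic carbon ortho to a hydroxy group had been seen carrying only nitro and carboxy, so it was unclear whether nitro was special there or carboxy was the exception. In this assay the step with bromo in place of carboxy gives a 25-fold lower number from compound 3 to compound 4 (1.40 log units; beyond the scatter) and the step with bromo in place of nitro gives no change at the digits printed from compound 2 to compound 4 (within the scatter) so bromo, a single heavy atom, matches nitro on this carbon while carboxy alone stands apart among the three groups seen there. The 3-bromo-4-hydroxyphenyl ring also matches the 3-hydroxy-4-nitrophenyl ring, with no change at the digits printed from compound 1 to compound 4 (within the scatter) but nothing measured here explains why carboxy stands apart.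

Still open, on these data alone, is whether a methyl ester, an amine or plain hydrogen on this same carbon would stay with bromo and nitro or fall with carboxy, which would show how narrowly the weaker result belongs to the carboxylic acid. Also open, as far as these compounds go, is whether the neighbouring hydroxy group matters, which a methoxy group in its place would begin to answer.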